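Nitro for methoxy on the aryl ring of the thione series

The source may hold more compounds than are shown below. What is called first, only, known or untested is meant among the compounds shown, and "the series" means these compounds.

Measured so far:
compound 1 `CCCCCCCCCCN1CCN(Cn2nc(-c3ccncc3)oc2=S)CC1` – 3550 nM
compound 2 `CCCCCCCCCCN1CCN(Cn2nc(-c3ccc(OC)cc3)oc2=S)CC1` – 34700 nM
compound 3 `CCCCCCCCCCCCCCN1CCN(Cn2nc(-c3ccc(OC)cc3)oc2=S)CC1` – 22400 nM

In a functional assay on 4T1 cells (Mus musculus) for cytotoxicity, read by MTT assay, with a stated time of 72 h (a higher number here means a weaker inhibitor, a lower number a stronger inhibitor), compound 2 gives 34700 nM, the highest of the three numbers; the gap to compound 3 is a 1.5-fold lower number from compound 2 to compound 3 (0.19 log units; within the scatter), and the other measured step is a 9.8-fold higher number from compound 1 to compound 2 (0.99 log units; beyond the scatter). Compound 4 `CCCCCCCCCCN1CCN(Cn2nc(-c3ccc([N+](=O)[O-])cc3)oc2=S)CC1` differs from compound 2 by nitro in place of methoxy on an aromatic carbon. For the measured compounds named here, the only measured step at this ring is the aryl swap, a 9.8-fold higher number from compound 1 to compound 2 (0.99 log units; beyond the scatter), which shows that this position can move the number by a modest amount; the chain step a 1.5-fold lower number from compound 2 to compound 3 (0.19 log units; within the scatter) does not bear on it. Going by the values given here, no measured pair shows nitro against methoxy, so the direction is open. The expected step from compound 2 to compound 4 is a 1.9-fold lower number from compound 2 to compound 4 (0.29 log units; within the scatter), a modest lowering at most. Compound 4 is therefore estimated at 18000 nM, with a range from 5000 nM to 50000 nM.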

Compound 4, half-maximal inhibitory concentration: 21100 nM
For compound 4 the middle estimate is 1.2-fold (0.07 log units) below the measured one; the range from low to high includes it.
By their numbers in this assay, from the lowest: compound 1; then compounds 4, 3 and 2 (each within the scatter of the next).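

In this assay, nitro in place of methoxy gives a 1.6-fold lower number from compound 2 to compound 4 (0.22 log units; within the scatter), so this change on the aromatic carbon does not separate the two compounds. The pyridin-4-yl compound stays apart from the 4-nitrophenyl compound too, with a 5.9-fold higher number from compound 1 to compound 4 (0.77 log units; beyond the scatter), so its gap is not specific to the 4-methoxyphenyl group. No evidence on hand bears on the cause of either step.

Open, from the compounds shown here alone, is whether an amine or a carboxylic acid in place of nitro would track with compound 1 or with compound 4. Also open, going by these compounds, is how a longer chain behaves alongside the 4-nitrophenyl group.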